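Swapping chlorine for bromine on a weak inhibitor

The source may hold more compounds than are shown below. What is called first, only, known or untested is meant among the compounds shown, and "the series" means these compounds.

Compound 1, with the structure `O=C(CCCc1ccccc1)Nc1nc2ccc(Cl)cc2c(=O)s1`, was tested in an assay on mitochondria (strain Sprague-Dawley) for inhibition of Amine oxidase [flavin-containing] B (Rattus norvegicus), read by fluorescence and Amplex Red, with stated times of 30 min and 45 min; on this read-out higher numbers stand for weaker inhibition and lower numbers for stronger inhibition. In this assay compound 1 gives > 10000 nM, which is a limit of the assay rather than a measured number. That means compound 1 sits at the limit of > 10000 nM in this assay, at which 1 of the 3 values shown sits, so only a lower bound of its inhibitory concentration is known.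

Two related compounds give real numbers. Compound 2, `O=C(C/C=C/c1ccccc1)Nc1nc2ccccc2c(=O)s1`, gives 361 nM in this assay. Compound 3, `O=C(CCCc1cccc(Cl)c1)Nc1nc2ccccc2c(=O)s1`, gives 6880 nM in this assay. Among the measured compounds shown here, since no single-point step links compound 1 to either of them, these values only show where the measured compounds fall, not how the change to compound 1 would move.

The new compound, compound 4, has the structure `O=C(CCCc1ccccc1)Nc1nc2ccc(Br)cc2c(=O)s1`. The change from compound 1 is bromo in place of chloro on an aromatic carbon. For the measured compounds named here, no measured pair in this set isolates such a swap, so no step size is known.

The expectation is that the step that the limit leaves unreadable from compound 1 to compound 4 will be small and not beyond the usual scatter, with no clear direction. Compound 4 is therefore estimated at 12000 nM, in the range 4000 nM to 40000 nM, and most likely it will again be reported only as a limit.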

Compound 4, half-maximal inhibitory concentration: > 10000 nM
Compound 4 was reported as a limit; the forecaster's own chance of this, stated with the estimate: 70%; the middle value is on the limit's open side.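

Compound 4, like compound 1, is reported only as a limit, so the effect of bromo in place of chloro on an aromatic carbon cannot be read as a step: the limit of > 10000 nM in this assay, at which 2 of the 4 values shown sit.

The compounds shown leave open how far either compound lies beyond that limit, and whether this swap changes inhibition at all.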